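The compounds below may be only part of what the source reports. "The series", "measured", "known", "first", "only" and "open" are said of these compounds alone.

In a functional assay on NCI-H23 cells (Homo sapiens) for antiproliferative activity, read by XTT assay (on this read-out lower numbers stand for stronger inhibition and higher numbers for weaker inhibition), the measured compounds stand as follows.
Compound 1 `O=c1c(Cc2coc3cccc(OCC4CCCCC4)c3c2=O)coc2ccccc12` gives 4130 nM.
Compound 2 `CC(C)COc1cccc2occ(Cc3coc4ccccc4c3=O)c(=O)c12` reaches only the limit of > 10000 nM.
Compound 3 `O=c1c(Cc2coc3ccccc3c2=O)coc2ccccc12` gives 1400 nM.

Compound 3 has the lowest of the two numbers; compound 1 is nearest, and compound 2 shows only a limit, as in the limit of > 10000 nM in this assay, at which 1 of the 3 values shown sits. Compound 4 `O=c1c(Cc2coc3cccc(OCc4ccccc4)c3c2=O)coc2ccccc12` differs from compound 3 by benzyloxy in place of hydrogen on an aromatic carbon. For the measured compounds named here, two measured steps bear on this: a 3.0-fold lower number from compound 1 to compound 3 (0.47 log units; beyond the scatter), and an at least 7.1-fold lower number from compound 2 to compound 3 (0.85 log units; beyond the scatter). Both ethers raised the number, so adding benzyloxy, a related ether, is expected to raise it too, probably in a 2.9-fold higher number from compound 3 to compound 4 (0.46 log units; beyond the scatter). Compound 4 is therefore estimated at 4000 nM, with a range from 1500 nM to 12000 nM.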

Compound 4, half-maximal inhibitory concentration: > 10000 nM
Compound 4 gave a limit, no number; the forecaster's own chance of this, stated with the estimate: 20%; at least 2.5-fold (0.39 log units) between middle value and limit.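

Benzyloxy on this aromatic carbon gives an at least 7.1-fold higher number from compound 3 to compound 4 (0.85 log units; beyond the scatter), so a third ether, this one carrying an aromatic ring, also raises the number over hydrogen. Phenyl in place of cyclohexyl gives an at least 2.4-fold higher number from compound 1 to compound 4 (0.38 log units; beyond the scatter), which leaves cyclohexylmethoxy as the only ether here with a measured number. Compound 2 and compound 4 each give a limit, not a number, so the step between them cannot be read: the limit of > 10000 nM in this assay, at which 2 of the 4 values shown sit.

Among the compounds shown, hydrogen gives the lowest number on this carbon. As far as these compounds go, whether a hydroxyl group or an amine there would go lower stays open.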